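Replacing the sulfonamide substituent of compound 1

This account rests on a few compounds, and the source may have more. Where it says the series, first, only, none or still open, it means among the compounds named here.

In a functional assay on DU-145 cells (Homo sapiens) for antiproliferative activity, read by sulforhodamine B assay, with a stated time of 72 h (on this read-out lower numbers stand for stronger inhibition and higher numbers for weaker inhibition), compound 1 (`Cc1cc(C)nc(NS(=O)(=O)c2ccc(Nc3nncc4ccccc34)cc2)n1`) gives 7.8 nM. Compound 2 (`Clc1ccc(C(/C=C/c2ccccc2)=N\Nc2nncc3ccccc23)cc1`) gives 4.6 nM and compound 3 (`Fc1ccc(Nc2nncc3ccccc23)cc1`) gives 4.3 nM, so compound 1 stands within the scatter of both. Compound 4 (`Cc1cc(NS(=O)(=O)c2ccc(Nc3nncc4ccccc34)cc2)no1`) carries 5-methyl-1,2-oxazol-3-yl in place of 4,6-dimethylpyrimidin-2-yl on a sulfonamide nitrogen. Among the compounds with values here, no measured pair differing in one place gauges this change directly. Still, compound 3, at 4.3 nM, has no sulfonamide at all and remains within the scatter of compound 1, so no step beyond the scatter is expected in this assay. The estimated step is a 1.0-fold higher number from compound 1 to compound 4 (0.01 log units; within the scatter). For compound 4 the expected value is 8 nM, with an estimated range of 3 nM to 25 nM.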

Compound 4, half-maximal inhibitory concentration: 35 nM
For compound 4 the middle estimate is 4.4-fold (0.64 log units) below the measured one; the whole stated range lies below it.
By their numbers in this assay, from the lowest: compounds 3, 2 and 1 (each within the scatter of the next); then compound 4.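

Exchanging 4,6-dimethylpyrimidin-2-yl for 5-methyl-1,2-oxazol-3-yl on a sulfonamide nitrogen gives, in this assay, a 4.5-fold higher number from compound 1 to compound 4 (0.65 log units; beyond the scatter) and so weakens inhibition. This is the first step beyond the scatter among these compounds, and it shows that the group at this position is not interchangeable, although compound 3 without any sulfonamide lies within the scatter of compound 1. Nothing available accounts for this step. The compounds shown leave open how a plain phenyl or a pyridin-2-yl on the same sulfonamide nitrogen would compare with compound 1 and compound 4.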